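Benzyl on the methyl-bearing ring: cytotoxicity notes

A few compounds are considered here, and "the series" means these few. Any claim that something is new, unique, unknown or untested is made for them only; others in the source may bear on it.

- compound 1 `COc1ccc2c(=O)cc(C)[nH]c2c1`: > 52800 nM
- compound 2 `COc1ccc2[nH]c(C)c(Br)c(=O)c2c1`: > 37300 nM

Both entries are limits, so neither gives a number for comparison. In an ADME assay on J774 cells (Mus musculus) for cytotoxicity (a lower number here means that less compound is needed, a higher number that more compound is needed for the effect), compound 1 stands only at a limit of > 52800 nM. Compound 2 likewise stands only at a limit of > 37300 nM. No half-maximal effective concentration has therefore been reached for either compound, and the two limits give no order between them.

The next compound is compound 3 `COc1ccc2c(=O)c(Cc3ccccc3)c(C)[nH]c2c1`. It differs from compound 1 by benzyl in place of hydrogen on an aromatic carbon, with benzyl in place of hydrogen on an aromatic carbon, ortho to a methyl group.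

Among the compounds with values here, no measured step shows what such a change does, so the expectation is a cautious one. Only a small shift towards lower values is expected in this assay, close to the scatter. The estimated step is an at least 1.7-fold lower number from compound 1 to compound 3 (0.24 log units; that floor lies within the scatter). A report of compound 3 as another limit is the more likely outcome. For compound 3, the expected value is 30000 nM, with an estimated range from 8000 nM to 60000 nM.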

Compound 3, half-maximal effective concentration in the J774 assay: > 35800 nM
Compound 3: a limit, no number (the forecaster's own chance of this, stated with the estimate: 70%); at least 1.1-fold (0.07 log units) between middle value and limit.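

In the J774 assay compound 3 gives > 35800 nM, which is a limit and not a number. In the J774 assay compound 1 gives > 52800 nM, which is also a limit and not a number. Within the data shown here, no step can therefore be read from compound 1 to compound 3. The compounds shown leave open whether benzyl in place of hydrogen on an aromatic carbon shifts the half-maximal effective concentration in the J774 assay at all. In a physicochemical assay for lipophilicity, at pH 7.4 (a higher number here means a more lipophilic compound, a lower number a more polar compound), compound 1 gives 1.2, and compound 3 gives 2.52.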